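This account rests on a few compounds, and the source may have more. Where it says the series, first, only, none or still open, it means among the compounds named here.

Measured compounds:
compound 1 `COc1cc2nc(/C=C/c3ccccc3)nc(N3CCC(CCNS(N)(=O)=O)CC3)c2cc1OC` gives 33% in an assay on cells for inhibition of Ectonucleotide pyrophosphatase/phosphodiesterase family member 1 (Homo sapiens), with a stated time of 60 min, tested at 1 uM; a lower number here means less inhibition, a higher number more inhibition at the concentration tested (going by the name of the read-out)
compound 2 `COc1cc2nc(/C=C/c3ccc(F)cc3)nc(N3CCC(CCNS(N)(=O)=O)CC3)c2cc1OC` gives 70% in this assay
compound 3 `COc1cc2ncnc(N3CCC(CCNC(C)=O)CC3)c2cc1OC` gives 9% in this assay

Compound 3 stands lowest of the three numbers; the values of compound 1 and compound 2 both lie above it, beyond the scatter. Within the data shown here, the only single-point step within the set is a number 37 percentage points higher from compound 1 to compound 2 (beyond the scatter), a fluoro in place of hydrogen on an aromatic carbon, which concerns a part of the molecule untouched here.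

Compound 4 `COc1cc2ncnc(N3CCC(CCN)CC3)c2cc1OC` differs from compound 3 by hydrogen in place of acetyl on an amine nitrogen. Among the measured compounds shown here, no measured step bears on this change, so nothing in the set argues for a move in either direction. The expectation is therefore a step of a number 1 percentage points higher from compound 3 to compound 4 (within the scatter) in this assay, within the scatter. Compound 4 is estimated at 10%, range 0% to 30%.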

Compound 4, a percentage reported as inhibition, at one concentration (the size of the read-out at that concentration, not a potency): 45%
Compound 4: middle estimate off by 35 percentage points, on the low side; the measured number lies above the stated range.
By their numbers in this assay, from the lowest: compound 3; then compound 1; then compound 4; then compound 2.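

In this assay the loss of acetyl from the amine nitrogen gives a number 36 percentage points higher from compound 3 to compound 4 (beyond the scatter) and so shows that this position strongly affects the read-out, which the earlier step on an aromatic carbon could not show. On this core, 2-aminoethyl gives the higher number and 2-acetamidoethyl the lower. Nothing available explains the size of this step.

From the compounds shown here alone, whether a carboxylic acid or a longer chain ending in an amine would hold or raise the number remains open. So does whether the free amine would give a similar step on the core of compound 2.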